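The source may report more compounds than this note shows. Statements on the series, on what has been measured and on what is new or still open speak of the compounds shown alone.

Compound 1 `CC(C)(C)c1ccc(C#N)cc1NC(=O)Nc1cccnc1` is the weaker of two compounds measured in a functional assay (aorta) for inhibition, with Rattus norvegicus as the target (a lower number here means a stronger inhibitor, a higher number a weaker inhibitor), where compound 1 gives 25700000 nM. Compound 2 `CC(C)(C)c1ccc(C#N)cc1NC(=O)Nc1ccc(Cl)nc1` gives 1600000 nM in this assay, and the step of a 16-fold lower number from compound 1 to compound 2 (1.21 log units; beyond the scatter) is the only one measured. Compound 3 `N#Cc1ccc(Oc2ccccc2)c(NC(=O)Nc2cccnc2)c1` differs from compound 1 by phenoxy in place of tert-butyl on an aromatic carbon. The measured step alters the other ring, at a different place, so it offers no direction for the change to compound 3; no step beyond the scatter is expected. For compound 3 the estimated value in this assay is 20000000 nM, within 3000000 nM to 100000000 nM, meaning the expected step of a 1.3-fold lower number from compound 1 to compound 3 (0.11 log units; within the scatter).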

Compound 3, half-maximal inhibitory concentration: 1000000 nM
Compound 3: the middle estimate sits 20-fold (1.30 log units) above what was measured, outside the stated range (below it).
By their numbers in this assay, from the lowest: compounds 3 and 2 (each within the scatter of the next); then compound 1.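

In this assay, the aromatic carbon para to a cyano group proves sensitive to its substituent: phenoxy in place of tert-butyl gives a 26-fold lower number from compound 1 to compound 3 (1.41 log units; beyond the scatter). Earlier, only the other ring had been seen to move the number, and now this ring does too, with a larger group that brings its own ring and an oxygen. Nothing available gives a cause for this drop.

From the compounds shown here alone, whether the oxygen or the ring of phenoxy matters stays open, and a methoxy group or a phenyl group here would separate the two. Also open, going by these compounds, is whether the chloro and phenoxy changes would add up in one compound.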